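Vero cytotoxicity limits across the chalcone amide series

The source may hold more compounds than are shown below. What is called first, only, known or untested is meant among the compounds shown, and "the series" means these compounds.

Measured compounds:
- Compound 1 `CCCOc1ccc(C(=O)/C=C/c2ccc(C(=O)Nc3cccc(-c4cc(C(=O)OC)no4)c3)cc2)cc1`; in an ADME assay on Vero cells (Chlorocebus sabaeus) for cytotoxicity, read by MTT assay, with a stated time of 72 h (a lower number here means that less compound is tolerated, a higher number that more compound is tolerated), compound 1 gives > 40 ug/mL, which is a limit of the assay.
- Compound 2 `COC(=O)c1cc(-c2cccc(NC(=O)c3ccc(/C=C/C(=O)c4ccccc4Br)cc3)c2)on1`; in this assay compound 2 gives > 40 ug/mL, again a limit.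
- Compound 3 `COC(=O)c1cc(-c2cccc(NC(=O)c3ccc(/C=C/C(=O)c4cccc(OC)c4)cc3)c2)on1`; in this assay compound 3 gives > 100 ug/mL, also a limit.

Compound 1 stands only at a limit in this assay, and the two further values are limits as well. Two of the three values sit at the limit of > 40 ug/mL in this assay, at which 2 of the 3 values shown sit, one at the limit of > 100 ug/mL in this assay, at which 1 of the 3 values shown sits. Every value is a limit. None of the steps among them can be read: a step that the two limits leave unreadable from compound 1 to compound 2, a step that the two limits leave unreadable from compound 1 to compound 3 and a step that the two limits leave unreadable from compound 2 to compound 3 all remain unreadable in size and direction.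

Compound 4 `COC(=O)c1cc(-c2cccc(NC(=O)c3ccc(/C=C/C(=O)c4ccccc4Cl)cc3)c2)on1` differs from compound 1 by 2-chlorophenyl in place of 4-propoxyphenyl on a carbonyl carbon. The nearest measured parallel is the step with 2-bromophenyl entering at the same carbonyl carbon, a step that the two limits leave unreadable from compound 1 to compound 2, which gave no readable size. Among the compounds with values here, no step bearing on this change is readable, so no change beyond the scatter can be expected in this assay from this evidence; the most probable outcome is another limit.

Compound 4 is therefore expected to give about 60 ug/mL in this assay, within 40 ug/mL to 150 ug/mL, and this estimate corresponds to a step that the limit leaves unreadable from compound 1 to compound 4 as an expectation only.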

Compound 4, half-maximal cytotoxic concentration: > 25 ug/mL
Compound 4 was reported as a limit; the forecaster's own chance of this, stated with the estimate: 80%; the middle value lies beyond the limit too.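

In this assay compound 4 gives > 25 ug/mL, which is a limit of the assay. The steps to compound 4 from compound 1, compound 2 and compound 3 cannot be read. The compounds shown leave open where the half-maximal cytotoxic concentration of each compound lies, and whether chloro in place of bromo on an aromatic carbon changes it.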